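A few compounds are considered here, and "the series" means these few. Any claim that something is new, unique, unknown or untested is made for them only; others in the source may bear on it.

Three compounds have been measured in a functional assay on MCF7 cells (Homo sapiens) for inhibition, read by CCK-8 assay, with a stated time of 48 h; on this read-out higher numbers stand for weaker inhibition of growth and lower numbers for stronger inhibition of growth:

Compound 1 `CN1CCN(c2ccc(Nc3ncc(Cl)c(Nc4ccccc4)n3)nc2)CC1`: 51800 nM
Compound 2 `Cc1ccc(CNc2nc(Nc3ccc(N4CCN(C)CC4)cn3)ncc2Cl)cc1`: 38100 nM
Compound 3 `COc1ccccc1CNc1nc(Nc2ccc(N3CCN(C)CC3)cn2)ncc1Cl`: > 100000 nM, a limit of the assay and not a number

Compound 3 stands at the limit of > 100000 nM in this assay, at which 1 of the 3 values shown sits, so it has no exact value of its own. Compound 4 `Cc1cccc(Nc2nc(Nc3ccc(N4CCN(C)CC4)cn3)ncc2Cl)c1` carries 3-methylphenyl in place of 2-methoxybenzyl on a nitrogen on an aromatic ring.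

Within the data shown here, three measured steps bear on this change, all at that same nitrogen. The first is an at least 1.9-fold higher number from compound 1 to compound 3 (0.28 log units; that floor lies within the scatter). The second is an at least 2.6-fold higher number from compound 2 to compound 3 (0.41 log units; beyond the scatter). The third, a 1.4-fold lower number from compound 1 to compound 2 (0.13 log units; within the scatter), shows that phenyl and 4-methylbenzyl are not told apart on these numbers. Of the groups measured, phenyl stands closest to 3-methylphenyl, and compound 1, which carries it, gives 51800 nM. Leaving 2-methoxybenzyl is thus expected to return the number to the range of the other two compounds, though the size of the step stays uncertain. In this assay the expected change, towards a lower number, is an at least 2.2-fold lower number from compound 3 to compound 4 (0.34 log units; beyond the scatter). For compound 4 the estimate is 45000 nM, with an expected range from 15000 nM to 100000 nM.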

Compound 4, concentration for 50% growth inhibition: 7160 nM
Compound 4: middle estimate off by 6.3-fold (0.80 log units), on the high side; the whole stated range lies above it.
By their numbers in this assay, from the lowest: compound 4; then compounds 2 and 1 (each within the scatter of the next). At a limit, above all of these: compound 3.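

Among the earlier compounds, phenyl and 4-methylbenzyl on this nitrogen could not be told apart, whereas in this assay a small addition to the phenyl group now separates clearly, with methyl in place of hydrogen on an aromatic carbon giving a 7.2-fold lower number from compound 1 to compound 4 (0.86 log units; beyond the scatter). The 3-methylphenyl group also separates from the benzyl groups, with a 5.3-fold lower number from compound 2 to compound 4 (0.73 log units; beyond the scatter) and an at least 13-fold lower number from compound 3 to compound 4 (1.14 log units; beyond the scatter), so compound 4 has the lowest number of the four, and replacing a benzyl group with an aromatic ring on the nitrogen does not by itself account for this, as compound 1 with phenyl goes against it. The step from compound 3 is only a floor, as compound 3 stands at a limit of the assay and not at a number: the limit of > 100000 nM in this assay, at which 1 of the 4 values shown sits.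

Whether the gain belongs to methyl in particular stays open, as the compounds shown do not include an ethyl group, a chlorine or a methoxy group in its place on the phenyl ring. They also leave open whether the place of the methyl on that ring matters, and whether the same step holds on a core with something other than chlorine.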